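A few compounds are considered here, and "the series" means these few. Any claim that something is new, unique, unknown or untested is made for them only; others in the source may bear on it.

Within the data shown here, in a functional assay on MCF7 cells (Homo sapiens) for inhibition, read by MTT assay (a lower number here means a stronger inhibitor, a higher number a weaker inhibitor), only two compounds have been read so far. Compound 1 `COc1cc2ncnc(Nc3ccc(NC(=O)c4ccc(C(C)(C)C)cc4)cc3)c2cc1OC`, with a 4-(tert-butyl)phenyl on the carbonyl carbon, gives > 100000 nM, which is a limit of the assay and not a number. Among the measured compounds shown here, compound 2 `COc1cc2ncnc(Nc3ccc(NC(=O)c4cccc(Cl)c4)cc3)c2cc1OC`, with a 3-chlorophenyl there, gives 18000 nM, the only true number available, so it has no measured neighbour to be ranked against. Compound 3 `COc1cc2ncnc(Nc3ccc(NC(=O)c4cccc(C(F)(F)F)c4)cc3)c2cc1OC` differs from compound 2 in one place, with trifluoromethyl in place of chloro on an aromatic carbon, meta to a large group: trifluoromethyl in place of chloro on an aromatic carbon. For the measured compounds named here, one measured step bears on this change, an at least 5.5-fold lower number from compound 1 to compound 2 (0.74 log units; beyond the scatter), which lies beyond the scatter. That step rests on (the limit of > 100000 nM in this assay, at which 1 of the 2 values shown sits). It exchanges the whole aryl group, not this single substituent, so it offers only loose guidance. A small shift toward a higher number in this assay is therefore expected, staying close to the scatter. The expected step is a 1.4-fold higher number from compound 2 to compound 3 (0.14 log units; within the scatter). Compound 3 is estimated at 25000 nM, with an expected range from 8000 nM to 80000 nM.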

Compound 3, half-maximal inhibitory concentration: > 100000 nM
Compound 3 ended at the assay's limit; the forecaster's own chance of this, stated with the estimate: 15%; middle value at least 4.0-fold (0.60 log units) away from the limit.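

In this assay, trifluoromethyl in place of chloro on this aromatic carbon, meta to a large group, gives an at least 5.5-fold higher number from compound 2 to compound 3 (0.74 log units; beyond the scatter), so the exchange of this one substituent is enough to take the series out of the readable range, which the earlier exchange of the whole aryl group could not show. Compound 3 gives > 100000 nM, which is a limit of the assay and not a number. The steps between the two compounds that end at a limit cannot be read, and the 3-chlorophenyl of compound 2 remains the only aryl group here with a true number, which leaves little to rank the series by: the limit of > 100000 nM in this assay, at which 2 of the 3 values shown sit.

The compounds shown leave open where the true values of compound 1 and compound 3 lie, and so whether those two differ at all. They also leave open how a fluoro, a methoxy or an amine at this same place would read against compound 2, and whether a plain hydrogen there would serve as well as chloro.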